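The source may report more compounds than this note shows. Statements on the series, on what has been measured and on what is new or still open speak of the compounds shown alone.

Three analogues built on the shared core have been examined in a functional assay on SK-BR-3 cells (Homo sapiens) for antiproliferative activity, read by MTT assay, with a stated time of 72 h; a lower number here means a stronger inhibitor, a higher number a weaker inhibitor. Compound 1 `C#CCOC(=O)C[C@@H]1C(C(=O)OC)=CO[C@@H](O[C@@H]2O[C@H](CO)[C@@H](O)[C@H](O)[C@H]2O)/C1=C/C` carries the unprotected sugar and a propargyl ester, compound 2 `C/C=C1/[C@H](O[C@@H]2O[C@H](COC(C)=O)[C@@H](OC(C)=O)[C@H](OC(C)=O)[C@H]2OC(C)=O)OC=C(C(=O)OC)[C@H]1CC(=O)O` carries the peracetylated sugar and a free carboxylic acid, and compound 3 `C/C=C1/[C@H](O[C@@H]2O[C@H](COC(C)=O)[C@@H](OC(C)=O)[C@H](OC(C)=O)[C@H]2OC(C)=O)OC=C(C(=O)OC)[C@H]1CC(=O)SCCC` is the propylsulfanyl thioester of that acid. In this assay compound 1 gives > 15000 nM, which is a limit of the assay rather than a number. Compound 2 likewise gives > 15000 nM, again only a limit. Compound 3 gives > 15000 nM, also a limit. For the measured compounds named here, because every value sits at the limit of > 15000 nM in this assay, at which 3 of the 3 values shown sit, the only single-place step among them, a step that the two limits leave unreadable from compound 2 to compound 3, cannot be read in size.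

Compound 4 `C/C=C1/[C@H](O[C@@H]2O[C@H](COC(C)=O)[C@@H](OC(C)=O)[C@H](OC(C)=O)[C@H]2OC(C)=O)OC=C(C(=O)OC)[C@H]1CC(=O)OCC` differs from compound 3 by ethoxy in place of propylsulfanyl on a carbonyl carbon. Going by the values given here, no measured step bears readably on this change: the one comparable step, from compound 2 to compound 3, is hidden by the two limits. The expectation is therefore that the step that the limit leaves unreadable from compound 3 to compound 4 shows nothing beyond the scatter and that compound 4 most likely returns another limit. Compound 4 is estimated at 20000 nM in this assay, with a range from 8000 nM to 60000 nM.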

Compound 4, half-maximal inhibitory concentration: > 15000 nM
Compound 4: a limit, no number (the forecaster's own chance of this, stated with the estimate: 85%); the middle value is on the limit's open side.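

In this assay compound 4 gives > 15000 nM, again a limit of the assay and not a number. Neither step to compound 4, from compound 2 or from compound 3, can be read in size, as every value shown stands at one limit: the limit of > 15000 nM in this assay, at which 4 of the 4 values shown sit.

The compounds shown leave open whether any group on this carbonyl carbon yields a measurable value in this assay.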